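Chloro for trifluoromethyl: a single-point change in a sedation-type screen

The source may report more compounds than this note shows. Statements on the series, on what has been measured and on what is new or still open speak of the compounds shown alone.

Measured compounds:
compound 1, `CCC(C(=O)N1CCN(c2cccc(C(F)(F)F)c2)CC1)N1C(=O)CC(C)C1=O`: 108 mg/kg
compound 2, `Cc1cccc(N2CCN(C(=O)C(C)N3C(=O)CC(C)C3=O)CC2)c1`: "not determined" (no result reported)

Within the data shown here, compound 1 is the only member of this small set with a number in a functional assay on the whole organism (strain Swiss) with Mus musculus as the target, with a stated time of 0.25 h; on this read-out lower numbers stand for an effect already at smaller amounts and higher numbers for an effect only at larger amounts of compound; compound 1 gives 108 mg/kg, and compound 2 carries "not determined" (no result reported) there, so there is nothing to set compound 1 against. Compound 3, `CCC(C(=O)N1CCN(c2cccc(Cl)c2)CC1)N1C(=O)CC(C)C1=O`, differs from compound 1 in one place: chloro in place of trifluoromethyl on an aromatic carbon. With no measured pair of this kind in the set, the size of the step is open. Since the rest of the molecule is untouched and only one substituent on the aromatic ring is exchanged, the step from compound 1 to compound 3 in this assay is expected to be modest and to stay within the usual scatter, with no clear direction. Compound 3 is therefore estimated at 100 mg/kg, within a range from 50 mg/kg to 220 mg/kg, which corresponds to an expected step of a 1.1-fold lower number from compound 1 to compound 3 (0.03 log units; within the scatter).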

Compound 3, dose for half-maximal effect: > 130 mg/kg
Compound 3: a limit, no number; the forecaster's own chance of this, stated with the estimate: 10%; middle value at least 1.3-fold (0.11 log units) away from the limit.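

Chloro in place of trifluoromethyl on this aromatic carbon gives an at least 1.2-fold higher number from compound 1 to compound 3 (0.08 log units; that floor lies within the scatter) in this assay. The result for compound 3 is a limit and not a number: the limit of > 130 mg/kg in this assay, at which 1 of the 3 values shown sits.

This gives the set its first comparison at this position, and the exchange shows no sign of an effect at smaller amounts, although it fixes only a floor for the step and not its size. The compounds shown leave open how large the step from trifluoromethyl to chloro really is, and whether it goes beyond the scatter. They also leave open how an amine or a carboxylic acid on the same aromatic carbon would read out in this assay, and whether either would shift the effect to smaller or larger amounts than trifluoromethyl does.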